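From 3-hydroxypropyl to 2-hydroxyethyl at compound 4

This account rests on a few compounds, and the source may have more. Where it says the series, first, only, none or still open, it means among the compounds named here.

In a physicochemical assay for solubility, in phosphate buffer, at pH 7.4 (on this read-out lower numbers stand for lower solubility and higher numbers for higher solubility), the measured compounds read:
- compound 1 `CCOCCc1cnc(NC(=O)NC)cc1Oc1cncc(C)c1` gives 500000 nM
- compound 2 `CNC(=O)Nc1cc(Oc2cncc(C)c2)c(CCCO)cn1` gives 500000 nM
- compound 3 `CNC(=O)Nc1cc(Oc2cncc(OC)c2)c([C@H]2CCCOC2)cn1` gives 303000 nM

Compound 2 stands level with compound 1, and compound 3 lies within the scatter of both. Compound 4 `CNC(=O)Nc1cc(Oc2cncc(C)c2)c(CCO)cn1` has not been measured yet. The change from compound 2 (hydroxy in place of hydroxymethyl on a saturated chain carbon, two bonds along the chain from an aromatic carbon) is hydroxy in place of hydroxymethyl on a saturated chain carbon, two bonds along the chain from an aromatic carbon, so 3-hydroxypropyl becomes 2-hydroxyethyl. Among the measured compounds shown here, one measured step at that same place bears on this: with no change at the digits printed from compound 1 to compound 2 (within the scatter) as the only guide, no step beyond the scatter is expected in this assay here. The expected step is a 1.1-fold lower number from compound 2 to compound 4 (0.05 log units; within the scatter) and stays within the scatter. Compound 4 is estimated at 450000 nM with an expected range from 250000 nM to 550000 nM for its measurement.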

Compound 4, solubility: 450000 nM
The estimate for compound 4 equals the measured number at the digits printed; low and high end bracket the measured number.
By their numbers in this assay, from the lowest: compounds 3, 4, 1 and 2 (each within the scatter of the next).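

In this assay, hydroxy in place of hydroxymethyl on a saturated chain carbon, two bonds along the chain from an aromatic carbon, gives a 1.1-fold lower number from compound 2 to compound 4 (0.05 log units; within the scatter), so 2-hydroxyethyl and 3-hydroxypropyl cannot be told apart here. Hydrogen in place of ethyl on the chain oxygen gives a 1.1-fold lower number from compound 1 to compound 4 (0.05 log units; within the scatter), so the free hydroxy and its ethyl ether cannot be told apart either. Nothing available explains why these chains read alike. Still open, on these data alone, is how a chain ending in an amine or a carboxylic acid would read at this position. A chain longer than these is open too.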